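A few compounds are considered here, and "the series" means these few. Any claim that something is new, unique, unknown or untested is made for them only; others in the source may bear on it.

Measured compounds in the series:

compound 1 `CN1CCN(c2ccc(Nc3ncc4nc(Nc5ccc(F)cc5)n([C@H]5CCCC(NC(=O)OC(C)(C)C)C5)c4n3)cc2)CC1` — 120 nM
compound 2 `CN1CCN(c2ccc(Nc3ncc4nc(Nc5ccc(F)cc5)n(-c5cccc(NC(=O)CO)c5)c4n3)cc2)CC1` — 7.5 nM
compound 3 `CN1CCN(c2ccc(Nc3ncc4nc(Nc5ccccc5)n([C@H]5CCN(C(=O)OC(C)(C)C)C5)c4n3)cc2)CC1` — 110 nM

In a functional assay on HCC827 cells (Homo sapiens) for antiproliferative activity, read by MTT assay, with a stated time of 72 h (a higher number here means a weaker inhibitor, a lower number a stronger inhibitor), compound 3 gives 110 nM. Compound 1 sits within the scatter of that number, so the two cannot be ordered; compound 2, with its 7.5 nM, is the only one of the three clearly apart from compound 3, and that gap lies beyond the scatter. Compound 3 therefore stands with compound 1 at the weaker end of the three numbers shown.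

Compound 4 `CN1CCN(c2ccc(Nc3ncc4nc(Nc5ccccc5)n([C@H]5CCNC5)c4n3)cc2)CC1` is not yet measured. It is obtained from compound 3 by the change (hydrogen in place of tert-butoxycarbonyl on an amine nitrogen in a ring), that is, hydrogen in place of tert-butoxycarbonyl on an amine nitrogen in a ring. Going by the values given here, no measured pair in this set shows the same change, so the size of the step is not anchored by data. The step of a 1.4-fold lower number from compound 3 to compound 4 (0.14 log units; within the scatter) is expected to stay within the usual scatter, perhaps leaning toward a slightly lower number. Compound 4 is accordingly estimated at 80 nM, with a plausible range from 20 nM to 400 nM in this assay.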

Compound 4, half-maximal inhibitory concentration: 530 nM
The estimate for compound 4 lay 6.6-fold (0.82 log units) below the measured number; measured number above the stated range.
By their numbers in this assay, from the lowest: compound 2; then compounds 3 and 1 (each within the scatter of the next); then compound 4.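

In this assay, going by these compounds alone, replacing tert-butoxycarbonyl with hydrogen on the amine nitrogen of the five-membered ring gives a 4.8-fold higher number from compound 3 to compound 4 (0.68 log units; beyond the scatter), the first measured single-place step. This position is therefore not indifferent to its substituent: going from 1-(tert-butoxycarbonyl)pyrrolidin-3-yl to pyrrolidin-3-yl, with its seven heavy atoms removed, costs activity beyond the scatter, and the unsubstituted ring nitrogen is not tolerated as well as the protected one. No measurement available here accounts for the size of this step.

Open, as far as these compounds go, is whether a small acyl group such as acetyl, a simple alkyl group such as methyl, or a longer chain on this ring nitrogen would sit closer to compound 3 or to compound 4. Also open, from the compounds shown here alone, is whether removing tert-butoxycarbonyl from compound 1 would give a step of similar direction and size.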